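Cytotoxic Tolerance of Three Analogues and an Expected Fourth

The source may hold more compounds than are shown below. What is called first, only, known or untested is meant among the compounds shown, and "the series" means these compounds.

Three compounds have been measured in a functional assay on HEK293 cells (Homo sapiens) for cytotoxicity; a lower number here means that less compound is tolerated, a higher number that more compound is tolerated:

compound 1, `COc1ccc([C@H]2CC(=O)N(Cc3cccc(N)c3)C2)cc1OC1CCCC1`, giving > 10000 nM;
compound 2, `COc1ccc([C@H]2CC(=O)N(c3ccccc3C#N)C2)cc1OC1CCCC1`, giving > 10000 nM;
compound 3, `COc1ccc([C@H]2CC(=O)N(c3cccc(NC(=O)C(C)=O)c3)C2)cc1OC1CCCC1`, giving > 10000 nM.

Each of these values is a limit of the assay rather than a number. Compound 3 therefore sits at the limit, and the same holds for compound 1 and for compound 2, as summarised by the limit of > 10000 nM in this assay, at which 3 of the 3 values shown sit. Among the compounds with values here, the only single-point step among the measured compounds, a step that the two limits leave unreadable from compound 1 to compound 2, runs between two limits and its size cannot be read.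

The unmeasured compound 4, `COc1ccc([C@H]2CC(=O)N(c3cccc(NS(=O)(=O)c4c(Br)nn(C)c4Cl)c3)C2)cc1OC1CCCC1`, differs from compound 3 by (3-bromo-5-chloro-1-methyl-1H-pyrazol-4-yl)sulfonyl in place of acetylcarbonyl on a nitrogen on an aromatic ring. Within the data shown here, no measured step touches this nitrogen on an aromatic ring, so the expectation rests on the fact that all three measured compounds, including compound 3, sit at the limit. Compound 4 is therefore expected to show a step of about a number no higher from compound 3 to compound 4 (the limit leaves the size open), that is, no change beyond the scatter. The estimate for compound 4 in this assay is 10000 nM, with a likely range from 4000 nM to 30000 nM, and it is expected that the assay will most probably again report only a limit for compound 4.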

Compound 4, half-maximal cytotoxic concentration: > 10000 nM
Compound 4: no number, only a limit; the forecaster's own chance of this, stated with the estimate: 70%; the middle value sits exactly at the limit.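

Compound 4 gives > 10000 nM in this assay as a limit of the assay and not a number. Compound 3 also stands at a limit, so no step can be read between compound 3 and compound 4, and the picture stays uniform: the limit of > 10000 nM in this assay, at which 4 of the 4 values shown sit.

The compounds shown leave open at what concentration, if any, each of the four would give an actual number in this assay and whether the exchanged group on the nitrogen changes it.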